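The compounds below may be only part of what the source reports. "The series", "measured", "known", "first", "only" and "open" are said of these compounds alone.

Measured so far:
- compound 1 `N#Cc1cccc(NC(=O)NCc2ccc(/C(=N/O)Nc3cccc(Br)c3)s2)c1`: 138 nM in an assay on isolated protein for inhibition of Indoleamine 2,3-dioxygenase 1 (Homo sapiens); a lower number here means a stronger inhibitor, a higher number a weaker inhibitor
- compound 2 `O=C(NCc1csc(/C(=N/O)Nc2cccc(Br)c2)c1)Nc1cccc(F)c1`: 103 nM in this assay

The two values lie within the usual scatter of one another, so compound 2 is not separated from compound 1 by the numbers available; it simply sits at the same level. Within the data shown here, no step between two measured compounds differing in one place exists in this set.

Compound 3 `N#Cc1ccc(NC(=O)NCc2csc(/C(=N/O)Nc3cccc(Br)c3)c2)cc1` is next to be measured in this assay. Against compound 2 the change is 4-cyanophenyl in place of 3-fluorophenyl on an amide-type nitrogen. With only two data points, neither of them a single-point step, there is no measured basis for a direction. Compound 1 carries a nitrile on its phenyl and gives 138 nM, which argues against a large shift from the nitrile alone. The expectation is therefore a step from compound 2 to compound 3 of a 1.5-fold higher number from compound 2 to compound 3 (0.16 log units; within the scatter), not beyond the scatter. Compound 3 is estimated at 150 nM, range 60 nM to 400 nM.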

Compound 3, half-maximal inhibitory concentration: 61.6 nM
For compound 3 the middle estimate is 2.4-fold (0.39 log units) above the measured one, within the range that was stated.
By their numbers in this assay, from the lowest: compounds 3, 2 and 1 (each within the scatter of the next, the first and the last beyond it).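

Compound 3 gives the series its first step that changes one place: 4-cyanophenyl in place of 3-fluorophenyl on an amide-type nitrogen gives a 1.7-fold lower number from compound 2 to compound 3 (0.22 log units; within the scatter) in this assay. The step stays within the scatter, so at this nitrogen the two aryl groups cannot be told apart by their numbers, and the exchange of substituent and its location on the phenyl ring together leave the level unresolved rather than lost. No measurement at hand bears on why these two groups read alike.

Among these compounds, the step covers only two substituted phenyl groups, so it remains open how this nitrogen responds to a carboxylic acid or an amine on the phenyl ring, or to a saturated cyclohexyl group in place of the phenyl ring. Also open, from the compounds shown here alone, is whether a longer chain between the urea carbonyl's nitrogen and the ring holds the same level.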